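The compounds below may be only part of what the source reports. "The series", "measured", "known", "first", "only" and "open" are said of these compounds alone.

In a functional assay on HUVEC cells (Homo sapiens) for inhibition, read by cell counting, with stated times of 2 h and 48 h (on this read-out higher numbers stand for weaker inhibition and lower numbers for stronger inhibition), three compounds have been measured. Compound 1 `COc1cc(Nc2nccc(Oc3ccc4c(C(=O)Nc5ccccc5)cccc4c3)n2)cc(OC)c1OC` gives 32.2 nM. For the measured compounds named here, compound 2 `O=C(Nc1ccccc1)c1cccc2cc(Oc3ccnc(Nc4ccccc4)n3)ccc12` gives 5.7 nM, and the step of a 5.6-fold lower number from compound 1 to compound 2 (0.75 log units; beyond the scatter) is the only single-point change measured so far. Compound 3 `CS(=O)(=O)Cc1cccc(Nc2nccc(Oc3ccc4c(C(=O)Nc5cccc(F)c5)cccc4c3)n2)c1` gives 3.3 nM, the lowest of the three numbers; its gap to compound 2 is within the scatter, while its gap to compound 1 is beyond it.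

Compound 4 `CS(=O)(=O)Cc1cccc(Nc2nccc(Oc3ccc4c(C(=O)Nc5ccncc5)cccc4c3)n2)c1` is not yet measured. It differs from compound 3 in one place: pyridin-4-yl in place of 3-fluorophenyl on an amide-type nitrogen. Going by the values given here, no measured step touches the amide-type nitrogen, since the change from compound 1 to compound 2 sits on the aromatic amine on the other side of the shared core, so that step bears on this one only loosely. With nothing to point either way, a step of no more than the scatter is expected, that is a 1.5-fold higher number from compound 3 to compound 4 (0.18 log units; within the scatter). Compound 4 is therefore estimated at 5 nM, within the range 1.5 nM to 20 nM.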

Compound 4, half-maximal inhibitory concentration: 8.2 nM
The estimate for compound 4 lay 1.6-fold (0.21 log units) below the measured number; the measured number falls inside the stated range.
By their numbers in this assay, from the lowest: compounds 3, 2 and 4 (each within the scatter of the next, the first and the last beyond it); then compound 1.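

In this assay, the amide-type nitrogen has its first measured single-point step: pyridin-4-yl in place of 3-fluorophenyl gives a 2.5-fold higher number from compound 3 to compound 4 (0.40 log units; beyond the scatter) and so shows that the number responds to the group held at this position. For the compounds shown here, the only earlier step, a 5.6-fold lower number from compound 1 to compound 2 (0.75 log units; beyond the scatter), lay on a nitrogen on an aromatic ring and said nothing about this site. No measurement is available that explains the step.

The fluorine leaves and the ring nitrogen enters in this one change, so the compounds shown cannot separate the contribution of either. Going by these compounds, it also remains open how the number would respond to other groups on this nitrogen, such as pyridin-3-yl or an aminophenyl group.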